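A few compounds are considered here, and "the series" means these few. Any claim that something is new, unique, unknown or untested is made for them only; others in the source may bear on it.

In a functional assay on PC-3 cells (Homo sapiens) for inhibition, read by MTT assay, with a stated time of 48 h, tested at 10 uM (a higher number here means more inhibition of growth at the concentration tested, a lower number less inhibition of growth), three compounds built on a shared core have been measured. Compound 1 (`Cc1cc(=O)c2c(O)cc(OCc3ccc(Br)cc3)c([C@H]3CCN(C)C[C@H]3O)c2o1`) gives 17%, compound 2 (`Cc1cc(=O)c2c(O)cc(O)c([C@H]3CCN(C)C[C@H]3OC(=O)c3ccco3)c2o1`) gives 23%, and compound 3 (`CCN(CC)Cc1c(O)c([C@H]2CCN(C)C[C@H]2O)c2oc(C)cc(=O)c2c1O`) gives 2%. Compound 3 is therefore the lowest of the three, beyond the scatter from both others. Compound 4 (`Cc1cc(=O)c2c(O)c(CN3CCCC3CO)c(O)c([C@H]3CCN(C)C[C@H]3O)c2o1`) differs from it on a saturated chain carbon bound to an aromatic carbon: 2-(hydroxymethyl)pyrrolidin-1-yl in place of diethylamino on a saturated chain carbon bound to an aromatic carbon. Among the measured compounds shown here, no measured pair shows what such a change does, so the data do not fix its size. A small rise is expected, with an estimated a number 6 percentage points higher from compound 3 to compound 4 (within the scatter), which would not clearly exceed the scatter. In this assay, the estimate for compound 4 is 8%, with the result expected between 0% and 22%.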

Compound 4, percent growth inhibition at one concentration: 15%
Compound 4: middle estimate off by 7 percentage points, on the low side, within the range that was stated.
By their numbers in this assay, from the lowest: compound 3; then compounds 4, 1 and 2 (each within the scatter of the next).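

The place on a saturated chain carbon bound to an aromatic carbon now proves sensitive to the amine it carries: in this assay, 2-(hydroxymethyl)pyrrolidin-1-yl in place of diethylamino gives a number 13 percentage points higher from compound 3 to compound 4 (beyond the scatter), a modest step. Among the compounds shown here, this is the first comparison in the set between compounds differing in one place. No measurement on hand accounts for the step.

The compounds shown leave open whether the ring or the hydroxymethyl carries this step. A plain pyrrolidin-1-yl at this place would separate the two.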